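The compounds below may be only part of what the source reports. "The series", "measured", "known", "first", "only" and "open" are said of these compounds alone.

Measured compounds:
compound 1, `O=C(CSc1cccc(O)c1)Nc1ccc2nc(NC(=O)c3cc(Cl)cc(Cl)c3)sc2c1`, 1530 nM;
compound 2, `O=C(CSc1cccc(O)c1)Nc1ccc2nc(NC(=O)c3cccs3)sc2c1`, 63000 nM;
compound 3, `Cc1cc(C)cc(C(=O)Nc2nc3ccc(NC(=O)CSc4cccc(O)c4)cc3s2)c1`, 2820 nM.

These three share one core and differ only in the group on the carbonyl carbon next to the amide-type nitrogen. In a functional assay on U2OS cells (Homo sapiens) for antiproliferative activity, read by MTT assay, with a stated time of 72 h (on this read-out higher numbers stand for weaker inhibition and lower numbers for stronger inhibition), compound 3 gives 2820 nM, the second highest of the three numbers; its nearest neighbour is compound 1, with a 1.8-fold higher number from compound 1 to compound 3 (0.27 log units; within the scatter), and its furthest is compound 2, with a 22-fold lower number from compound 2 to compound 3 (1.35 log units; beyond the scatter). The other step, a 41-fold higher number from compound 1 to compound 2 (1.61 log units; beyond the scatter), shows the same large movement when thiophen-2-yl replaces a substituted phenyl.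

Compound 4, `O=C(CSc1cccc(O)c1)Nc1ccc2nc(NC(=O)c3ccccc3)sc2c1`, has not yet been measured. It differs from compound 3 by phenyl in place of 3,5-dimethylphenyl on a carbonyl carbon. For the measured compounds named here, no measured step removes both methyl groups from this phenyl, so the closest guide is the small step between the two substituted phenyls, a 1.8-fold higher number from compound 1 to compound 3 (0.27 log units; within the scatter), which stays within the scatter, while the large steps of a 41-fold higher number from compound 1 to compound 2 (1.61 log units; beyond the scatter) and a 22-fold lower number from compound 2 to compound 3 (1.35 log units; beyond the scatter) concern a different ring entirely and bear only loosely on this change. Compound 4 is therefore expected to land near compound 3, with at most a modest rise in this assay, expected as a 1.6-fold higher number from compound 3 to compound 4 (0.20 log units; within the scatter). The estimate for compound 4 is 4500 nM, with a range from 1500 nM to 14000 nM.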

Compound 4, half-maximal inhibitory concentration: > 100000 nM
Compound 4 gave a limit, no number; the forecaster's own chance of this, stated with the estimate: 5%; at least 22-fold (1.34 log units) between middle value and limit.
By their numbers in this assay, from the lowest: compounds 1 and 3 (each within the scatter of the next); then compound 2. At a limit, above all of these: compound 4.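

The value of compound 4 is a limit of the assay and not a number: the limit of > 100000 nM in this assay, at which 1 of the 4 values shown sits. Compounds 1 and 3 lie within the scatter of each other, yet the loss of both methyl groups gives an at least 35-fold higher number from compound 3 to compound 4 (1.54 log units; beyond the scatter), and the loss of both chlorines gives an at least 65-fold higher number from compound 1 to compound 4 (1.81 log units; beyond the scatter), so among these compounds a phenyl ring on this carbonyl carbon does not by itself carry the activity, and the activity appears only with the two substituents present, whether methyl or chloro. The third comparison gives an at least 1.5-fold higher number from compound 2 to compound 4 (0.20 log units; that floor lies within the scatter); that floor lies within the scatter, so phenyl does not recover what thiophen-2-yl lost, and the large steps seen earlier with thiophen-2-yl can no longer be read as the effect of leaving a phenyl ring.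

Going by these compounds, it remains open whether a single methyl or a single chlorine on the phenyl would be enough, and whether a methoxy, an amine or a carboxylic acid in those places would serve as the two methyl groups do. The compounds shown also give no reason for the step, and they say nothing of how it would look outside this assay.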